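The compounds below may be only part of what the source reports. "The series", "measured", "known", "first", "only" and "open" are said of these compounds alone.

Compound 3 `COc1ccc(-c2ccc(N(C[C@@H](N)CC(C)C)C(=O)[C@@H]3C[C@H]3c3ccccc3)cc2)cc1` gives the lowest number of the three measured: in a functional assay for agonist activity at G protein-coupled receptor 88 (Homo sapiens), read by HTRF and cAMP accumulation (on this read-out lower numbers stand for an effect already at smaller amounts and higher numbers for an effect only at larger amounts of compound), compound 3 gives 330 nM, whereas compound 1 `CC(C)C[C@H](N)CN(C(=O)[C@@H]1C[C@H]1c1ccccc1)c1ccc(-c2ccccc2)cc1` gives 880 nM and compound 2 `CC(C)C[C@H](N)CN(C(=O)[C@@H]1C[C@H]1c1ccccc1)c1ccc(C2=CCCC2)cc1` gives 1200 nM. The steps of a 2.7-fold lower number from compound 1 to compound 3 (0.43 log units; beyond the scatter) and a 3.6-fold lower number from compound 2 to compound 3 (0.56 log units; beyond the scatter) both lie beyond the scatter, while a 1.4-fold higher number from compound 1 to compound 2 (0.13 log units; within the scatter) does not. Compound 4 `CC(C)C[C@H](N)CN(C(=O)[C@@H]1C[C@H]1c1ccccc1)c1ccc(-c2cccc(F)c2)cc1` differs from compound 3 by 3-fluorophenyl in place of 4-methoxyphenyl on an aromatic carbon. For the measured compounds named here, the measured step of a 2.7-fold lower number from compound 1 to compound 3 (0.43 log units; beyond the scatter) bears on it most directly: it shows the methoxy being added, and compound 4 gives that group up and gains fluorine, a change no measured step covers. The number for compound 4 is therefore expected to move back toward that of compound 1, a step of a 2.3-fold higher number from compound 3 to compound 4 (0.36 log units; beyond the scatter). Compound 4 is estimated at 750 nM, within 300 nM to 1800 nM.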

Compound 4, half-maximal effective concentration: 2100 nM
Estimate against measurement, compound 4: 2.8-fold (0.45 log units) below; the measured number lies above the stated range.
By their numbers in this assay, from the lowest: compound 3; then compounds 1, 2 and 4 (each within the scatter of the next, the first and the last beyond it).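

Substitution on this phenyl does not act in one direction: fluoro in place of hydrogen gives a 2.4-fold higher number from compound 1 to compound 4 (0.38 log units; beyond the scatter), against a 2.7-fold lower number from compound 1 to compound 3 (0.43 log units; beyond the scatter) for methoxy. Exchanging 4-methoxyphenyl for 3-fluorophenyl is the largest change seen so far, a 6.4-fold higher number from compound 3 to compound 4 (0.80 log units; beyond the scatter), whereas a 1.8-fold higher number from compound 2 to compound 4 (0.24 log units; within the scatter) does not separate 3-fluorophenyl from cyclopent-1-en-1-yl. No measurement shown explains these differences.

The compounds shown do not separate the identity of the added group from where it sits on the ring. From the compounds shown here alone, how an amine or a nitrile on that ring would read remains open.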